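The compounds below may be only part of what the source reports. "The series", "measured", "known", "first", "only" and "open" are said of these compounds alone.

Within the data shown here, in a functional assay on HCT-15 cells (Homo sapiens) for cytotoxicity, read by ELISA, with a stated time of 2 days (on this read-out higher numbers stand for weaker inhibition and lower numbers for stronger inhibition), compound 1 `Oc1cccc(-c2cc(-c3ccccc3)nc(-c3ccccc3)c2)c1` gives 18000 nM and compound 2 `Oc1cccc(-c2cc(-c3ccccc3)nc(-c3ccccn3)c2)c1` gives 20900 nM, so compound 2 stands level with the only other measured compound. Compound 3 `Oc1cccc(-c2cc(-c3ccccc3)nc(-c3ccncc3)c2)c1` carries pyridin-4-yl in place of pyridin-2-yl on an aromatic carbon. Among the measured compounds shown here, the one measured step that bears on this change, pyridin-2-yl in place of phenyl, is small: a 1.2-fold higher number from compound 1 to compound 2 (0.06 log units; within the scatter). No step beyond the scatter is therefore expected in this assay, and the estimated change is a 1.1-fold lower number from compound 2 to compound 3 (0.04 log units; within the scatter). Compound 3 is expected at about 19000 nM, within a range of 9000 nM to 40000 nM.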

Compound 3, half-maximal inhibitory concentration: 18700 nM
The estimate for compound 3 lay 1.0-fold (0.01 log units) above the measured number, within the range that was stated.
By their numbers in this assay, from the lowest: compounds 1, 3 and 2 (each within the scatter of the next).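

Moving the ring nitrogen from pyridin-2-yl to pyridin-4-yl gives a 1.1-fold lower number from compound 2 to compound 3 (0.05 log units; within the scatter) and putting pyridin-4-yl in place of phenyl gives a 1.0-fold higher number from compound 1 to compound 3 (0.02 log units; within the scatter). So in this assay neither having a ring nitrogen in this group nor where it sits separates these three compounds. No measurement shown offers an explanation for this. From the compounds shown here alone, it remains open whether pyridin-3-yl, or a different kind of group at this position such as an amine or a carboxylic acid, would move the number beyond the scatter. Going by these compounds, the role of the 3-hydroxyphenyl group also remains open.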